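A few compounds are considered here, and "the series" means these few. Any claim that something is new, unique, unknown or untested is made for them only; others in the source may bear on it.

In a functional assay on the whole organism (strain albino) for inhibition, with Rattus norvegicus as the target, read by paw edema, with stated times of 30 min and 3 h, at a dose of 25 mg/kg by the intraperitoneal route (on this read-out higher numbers stand for more inhibition at the one dose given (going by the name of the read-out) and lower numbers for less inhibition), three compounds have been measured so far:
compound 1 `CCOC(=O)c1nn(-c2ccccc2)c(-c2ccc(OC)cc2OC)c1C` gives 5.81%;
compound 2 `COc1ccc(C2=NN(C(=O)NS(=O)(=O)c3ccc(Cl)cc3)CC2c2ccccc2)c(OC)c1` gives 25.7%;
compound 3 `COc1ccc(C2=NN(C(=O)NS(=O)(=O)c3ccc(Cl)cc3)CC2C)c(OC)c1` gives 16.5%.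

Compound 2 stands highest of these three numbers, yet its distance to compound 3 is within the usual scatter, and only compound 1 lies clearly lower. Compound 4 `COc1ccc(C2=NN(C(=O)NS(=O)(=O)c3ccc(C)cc3)CC2c2ccccc2)c(OC)c1` differs from compound 2 in one place: methyl in place of chloro on an aromatic carbon. Within the data shown here, the only measured step, a number 9.2 percentage points lower from compound 2 to compound 3 (within the scatter), concerns a different position, a saturated ring carbon, and was itself within the scatter, so no measured step bears directly on this exchange. With nothing in the shown numbers pointing to a shift, the step from compound 2 to compound 4 in this assay is expected to be a number 2.7 percentage points lower from compound 2 to compound 4 (within the scatter), no more than scatter. Compound 4 is therefore estimated at 23%, within a range from 10% to 36%.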

Compound 4, a percentage reported as inhibition, in the whole organism at one dose (the size of the read-out at that dose, not a potency): 4.83%
Compound 4: the middle estimate sits 18.2 percentage points above what was measured; the measured number lies below the stated range.
By their numbers in this assay, from the lowest: compounds 4 and 1 (each within the scatter of the next); then compounds 3 and 2 (each within the scatter of the next).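

In this assay methyl in place of chloro, on the aromatic carbon para to a large group, gives a number 20.9 percentage points lower from compound 2 to compound 4 (beyond the scatter) and so shows that this position responds to a change of one heavy atom. The earlier compounds shown here offered only a step at a saturated ring carbon, and that step stayed within the scatter. Nothing available explains this drop. Only chloro and methyl are shown at this position, so the effect of an amine or a carboxylic acid there remains open. Also open, going by these compounds, is whether the same exchange would give a similar step in compound 3, which carries methyl on the saturated ring carbon.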